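Methoxy to hydrogen on the shared core: next step

This account rests on a few compounds, and the source may have more. Where it says the series, first, only, none or still open, it means among the compounds named here.

The series is assessed in a functional assay on SK-MEL-28 cells (Homo sapiens) for inhibition, read by sulforhodamine B assay, with a stated time of 48 h; a lower number here means a stronger inhibitor of growth, a higher number a weaker inhibitor of growth. Compound 1 `COc1ccc(-c2cc(/C=C/C(=O)c3ccc(N)cc3)[nH]n2)cc1` gives 1870 nM. Compound 2 `COc1ccc(-c2cc(/C=C/C(=O)c3ccc(N)cc3)[nH]n2)cc1OC` gives 2140 nM. Compound 3 `COc1cc(C(=O)/C=C/c2cc(-c3cc(OC)c(OC)c(OC)c3)n[nH]2)cc(OC)c1OC` gives 1820 nM, and this value sits alongside those of compound 1 and compound 2 within the usual scatter, so no order among the three is claimed. The difference between the cores of compound 2 and compound 3 is not broken down here.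

For the measured compounds named here, the one measured pair that differs in a single place shows (hydrogen in place of methoxy on an aromatic carbon). The step that went with it was a 1.1-fold lower number from compound 2 to compound 1 (0.06 log units; within the scatter).

Compound 4 `COc1ccc(-c2cc(/C=C/C(=O)c3cc(OC)c(OC)c(OC)c3)[nH]n2)cc1OC` is not yet measured. It arises from compound 3 by hydrogen in place of methoxy on an aromatic carbon. This is the same kind of change as that from compound 2 to compound 1, not the same: around the place it differs in that the carbon losing the methoxy in compound 3 is also meta to a methoxy group, which the earlier pair did not have.

In this assay the step from compound 3 to compound 4 is expected to be small, a 1.0-fold higher number from compound 3 to compound 4 (0.02 log units; within the scatter). This rests on the measured pair, since a 1.1-fold lower number from compound 2 to compound 1 (0.06 log units; within the scatter) was within the scatter, and the extra methoxy around the place gives no measured ground to expect otherwise. Compound 4 is accordingly estimated at 1900 nM, with a likely span from 950 nM to 3800 nM.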

Compound 4, concentration for 50% growth inhibition: 1910 nM
Compound 4: the middle estimate sits 1.0-fold (0.00 log units) below what was measured; low and high end bracket the measured number.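

In this assay, hydrogen in place of methoxy on an aromatic carbon on the core of compound 3 gives a small step, a 1.0-fold higher number from compound 3 to compound 4 (0.02 log units; within the scatter), and this place is ortho to a methoxy group and meta to a methoxy group. Set beside the earlier case, the change reads the same on both cores, with no difference between them: the same change on two cores in this assay, a 1.1-fold lower number (0.06 log units; within the scatter) from compound 2 to compound 1 and a 1.0-fold higher number (0.02 log units; within the scatter) from compound 3 to compound 4, 1.2-fold (0.08 log units) apart, within the scatter of two such steps. This shows only that, on these two cores, the loss of this one methoxy leaves no readable mark on the number, and it does not show that the same would hold on any other core, or that the remaining methoxy groups could go without consequence, since each core offers a single step and neither step lies beyond the scatter.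

Still open, on these data alone, is whether a group other than hydrogen at this place, such as a hydroxyl, a fluorine or a longer alkoxy chain, would give a step beyond the scatter. Also open, as far as these compounds go, is what a carboxylic acid would do in place of the amine of compound 1 and compound 2, or what a ring stripped of every methoxy group would give.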